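Compound 3 to compound 4: cyanothiophene replaces thiazole

The source may hold more compounds than are shown below. What is called first, only, known or untested is meant among the compounds shown, and "the series" means these compounds.

In an in vitro ADME assay on microsomes from liver (Homo sapiens) for metabolic stability (a lower number here means slower removal, a higher number faster removal of the compound), compound 1 `O=C(COCc1cnccn1)N1CCN(c2ccc(Cl)cc2Cl)CC1` gives 4 mL.min-1.g-1 while compound 2 `O=C(COCc1cncs1)N1CCN(c2ccc(Cl)cc2Cl)CC1` gives 73 mL.min-1.g-1 and compound 3 `O=C(COCc1nccs1)N1CCN(c2ccc(Cl)cc2Cl)CC1` gives 80 mL.min-1.g-1, so compound 3 shares the high end of the three numbers with compound 2.

Compound 4 `N#Cc1ccc(COCC(=O)N2CCN(c3ccc(Cl)cc3Cl)CC2)s1` carries 5-cyanothiophen-2-yl in place of 1,3-thiazol-2-yl on a saturated chain carbon bound to an oxygen on a saturated carbon.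

Three measured steps at this place bear on it. Two are large, an 18-fold higher number from compound 1 to compound 2 (1.26 log units; beyond the scatter) and a 20-fold higher number from compound 1 to compound 3 (1.30 log units; beyond the scatter), and both leave pyrazin-2-yl. The third, a 1.1-fold higher number from compound 2 to compound 3 (0.04 log units; within the scatter), stays within the scatter. No thiophene has been measured, so the reference is the thiazole pair, and no step beyond the scatter is expected (a 1.3-fold lower number from compound 3 to compound 4 (0.12 log units; within the scatter)). For compound 4 the estimated value is 60 mL.min-1.g-1, with an expected range of 20 mL.min-1.g-1 to 150 mL.min-1.g-1.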

Compound 4, intrinsic clearance in microsomes: 110 mL.min-1.g-1
Compound 4: middle estimate off by 1.8-fold (0.26 log units), on the low side; the range from low to high includes it.
By their numbers in this assay, from the lowest: compound 1; then compounds 2, 3 and 4 (each within the scatter of the next).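

In this assay 5-cyanothiophen-2-yl at this place stays with both thiazoles (a 1.4-fold higher number from compound 3 to compound 4 (0.14 log units; within the scatter); a 1.5-fold higher number from compound 2 to compound 4 (0.18 log units; within the scatter)), while the gap to pyrazin-2-yl remains (a 28-fold higher number from compound 1 to compound 4 (1.44 log units; beyond the scatter)). Among the compounds shown here, a ring with one hetero atom and a nitrile therefore joins the two rings with two hetero atoms, and compound 1 remains the only low number. No evidence on the source of this gap is available.

On these data alone, whether the low number is specific to pyrazin-2-yl or also comes with pyridin-2-yl or pyrimidin-2-yl remains open. As far as these compounds go, how unsubstituted thiophen-2-yl compares with compound 4 also remains open.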